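The source may hold more compounds than are shown below. What is called first, only, known or untested is meant among the compounds shown, and "the series" means these compounds.

Measured so far in a functional assay on K562 cells (Homo sapiens) for cytotoxicity, read by sulforhodamine B assay; on this read-out lower numbers stand for higher toxicity in this test and higher numbers for lower toxicity in this test:
- compound 1 `CC1=CC[C@@H]([C@@](C)(O)CCCC(C)(C)NC(=S)N/N=C\c2ccc(C)cc2)CC1`: > 100000 nM
- compound 2 `CC1=CC[C@@H]([C@@](C)(O)CCCC(C)(C)NC(=S)N/N=C\c2ccccc2Cl)CC1`: 8500 nM

The entry for compound 1 is a limit of this assay, not a number. Among the measured compounds shown here, that leaves compound 2 with the only true number so far, 8500 nM.

Compound 3 `CC1=CC[C@@H]([C@@](C)(O)CCCC(C)(C)NC(=S)N/N=C\c2ccc(Cl)cc2)CC1` keeps everything in compound 2 except the chlorophenyl group: 4-chlorophenyl in place of 2-chlorophenyl on a carbon with a double bond to nitrogen. For the measured compounds named here, the only measured step, an at least 11-fold lower number from compound 1 to compound 2 (1.07 log units; beyond the scatter), is large, but it changed the group and its substitution number together, so it bears on this change only in part. Compound 3 keeps the chlorine of compound 2, while its name shares the 4 of the 4-methylphenyl in compound 1, so some of that large step may be given back. The expected change, a 2.0-fold higher number from compound 2 to compound 3 (0.30 log units; within the scatter), is moderate and points towards a higher number, meaning lower toxicity. For compound 3 the estimated value is 17000 nM, with an expected range of 4500 nM to 70000 nM.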

Compound 3, concentration lethal to 50% of the cells: 10300 nM
Compound 3: middle estimate off by 1.7-fold (0.22 log units), on the high side; the measured number falls inside the stated range.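

Moving the chlorine, from 2-chlorophenyl to 4-chlorophenyl on a carbon with a double bond to nitrogen, gives a 1.2-fold higher number from compound 2 to compound 3 (0.08 log units; within the scatter), so this assay does not separate these two placements. Compound 3 also allows a cleaner comparison than the earlier pair, as only the group on the aromatic carbon changes: chloro in place of methyl gives an at least 9.7-fold lower number from compound 1 to compound 3 (0.98 log units; beyond the scatter), so the earlier large step goes with the chlorine rather than with where it sits. The full size of this step stays unknown, because the entry for compound 1 is a limit and not a number: the limit of > 100000 nM in this assay, at which 1 of the 3 values shown sits.

Open, as far as these compounds go, is whether chlorine itself matters or other groups on the aromatic ring would serve equally. Bromo, methoxy, trifluoromethyl or an amine, or plain phenyl with no such group, could test this.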